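Trifluoromethoxy for trifluoromethyl in a glucagon receptor series

A few compounds are considered here, and "the series" means these few. Any claim that something is new, unique, unknown or untested is made for them only; others in the source may bear on it.

Compound 1, `O=C(O)CCNC(=O)c1ccc(CN(c2ccc(Cl)cc2)c2nc(-c3ccc(C(F)(F)F)cc3)cs2)cc1`, gives 53 nM in an in vitro assay on BHK cells for binding affinity to Glucagon receptor (Homo sapiens); a higher number here means a weaker inhibitor, a lower number a stronger inhibitor.
Compound 2, `Cc1cc(N(Cc2ccc(C(=O)NCCC(=O)O)cc2)c2nc(-c3ccc(C(F)(F)F)cc3)cs2)ccc1C(C)C`, gives 93 nM in this assay.
Compound 3, `O=C(O)CCNC(=O)c1ccc(CN(c2ccc3c(c2)CCC3)c2nc(-c3ccc(C(F)(F)F)cc3)cs2)cc1`, gives 64 nM in this assay.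

Compound 1 holds the lowest of the three numbers, yet a 1.2-fold higher number from compound 1 to compound 3 (0.08 log units; within the scatter) and a 1.8-fold higher number from compound 1 to compound 2 (0.24 log units; within the scatter) both fall within the scatter, as does a 1.5-fold lower number from compound 2 to compound 3 (0.16 log units; within the scatter). Compound 4, `O=C(O)CCNC(=O)c1ccc(CN(c2ccc(Cl)cc2)c2nc(-c3ccc(OC(F)(F)F)cc3)cs2)cc1`, is reached from compound 1 by trifluoromethoxy in place of trifluoromethyl on an aromatic carbon. Within the data shown here, none of the measured steps touches this part of the molecule: all three vary only the aryl on the nitrogen. Among the measured compounds shown here, no measured step therefore bears on the change, and in this assay a step not beyond the scatter is expected. Compound 4 is estimated at 60 nM, within 25 nM to 150 nM. This estimate means a 1.1-fold higher number from compound 1 to compound 4 (0.05 log units; within the scatter) is expected.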

Compound 4, half-maximal inhibitory concentration: 53 nM
Estimate against measurement, compound 4: 1.1-fold (0.05 log units) above, and the stated range covers the measured number.
By their numbers in this assay, from the lowest: compounds 1, 4, 3 and 2 (each within the scatter of the next).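

Compound 4 is the only compound shown that changes the 4-(trifluoromethyl)phenyl group rather than the aryl on the nitrogen. In this assay, trifluoromethoxy in place of trifluoromethyl gives no change at the digits printed from compound 1 to compound 4 (within the scatter), so this position accepts the added oxygen with no visible loss when 4-chlorophenyl sits on the nitrogen. Nothing available gives a reason for this result. Still open, going by these compounds, is how a methoxy group, a nitrile or an amine would read at this position. On these data alone, it is also open whether trifluoromethoxy gives the same result alongside 4-isopropyl-3-methylphenyl or 2,3-dihydro-1H-inden-5-yl on the nitrogen.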